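The source may report more compounds than this note shows. Statements on the series, on what has been measured and on what is new or still open speak of the compounds shown alone.

Compound 1 `COc1ccc(Nc2nc(SCc3cn(Cc4ccccc4Cl)nn3)nc(-c3ccccc3)c2C#N)cc1` gives 7960 nM in a functional assay on ECa-109 cells (Homo sapiens) for inhibition, read by MTT assay, with a stated time of 72 h; a lower number here means a stronger inhibitor, a higher number a weaker inhibitor. Compound 2 `N#Cc1c(Nc2cccc(C(F)(F)F)c2)nc(SCc2cn(Cc3ccccc3Cl)nn2)nc1-c1ccccc1` gives 32000 nM in this assay. Compound 3 `N#Cc1c(Nc2cccc([N+](=O)[O-])c2)nc(SCc2cn(Cc3ccccc3Cl)nn2)nc1-c1ccccc1` reaches only the limit of this assay, > 64000 nM.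

Compound 3 thus stands at the ceiling of the numbers shown, at the limit of > 64000 nM in this assay, at which 1 of the 3 values shown sits, and no numerical value is known for it. Compound 4 `N#Cc1c(Nc2ccccc2F)nc(SCc2cn(Cc3ccccc3Cl)nn2)nc1-c1ccccc1` differs from it in one place: 2-fluorophenyl in place of 3-nitrophenyl on a nitrogen on an aromatic ring. Two measured steps lead into compound 3, an at least 8.0-fold higher number from compound 1 to compound 3 (0.90 log units; beyond the scatter) and an at least 2.0-fold higher number from compound 2 to compound 3 (0.30 log units; that floor lies within the scatter), both raising the number. Leaving 3-nitrophenyl is therefore expected to lower the number, and the step of an at least 3.2-fold lower number from compound 3 to compound 4 (0.50 log units; beyond the scatter) is estimated in that direction. Compound 4 is estimated at 20000 nM, with a range from 6000 nM to 64000 nM.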

Compound 4, half-maximal inhibitory concentration: 23000 nM
Beside the measured number, compound 4's estimate is 1.2-fold (0.06 log units) below it, and the stated range covers the measured number.
By their numbers in this assay, from the lowest: compound 1; then compounds 4 and 2 (each within the scatter of the next). At a limit, above all of these: compound 3.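

Putting 2-fluorophenyl in place of 3-nitrophenyl on this nitrogen gives an at least 2.7-fold lower number from compound 3 to compound 4 (0.44 log units; beyond the scatter) and so moves the reading from a limit to a number. With a 1.4-fold lower number from compound 2 to compound 4 (0.14 log units; within the scatter) the 2-fluorophenyl and 3-(trifluoromethyl)phenyl groups cannot be told apart here. Yet a 2.9-fold higher number from compound 1 to compound 4 (0.46 log units; beyond the scatter) shows that 2-fluorophenyl does not reach 4-methoxyphenyl, which keeps the lowest number of the four.

The compounds shown leave open how an unsubstituted phenyl, a 4-hydroxyphenyl or a cyclohexyl group on this nitrogen would compare with 4-methoxyphenyl.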